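This account rests on a few compounds, and the source may have more. Where it says the series, first, only, none or still open, it means among the compounds named here.

Measured so far in a physicochemical assay for lipophilicity, read by HPLC, at pH 7.5; on this read-out higher numbers stand for higher lipophilicity and lower numbers for lower lipophilicity:
Compound 1 `CC[C@@H](Nc1c(C#N)c(-c2ccc(-c3cccc(Cl)c3)cc2)nc2cnccc12)C(N)=O`: 3.1
Compound 2 `CC[C@@H](Nc1c(C#N)c(-c2ccc(-c3ccccc3OC)cc2)nc2cnccc12)C(N)=O`: 2.7

Among the compounds with values here, compound 2 holds the lower of the two numbers, and the only measured step is a number 0.40 log units lower from compound 1 to compound 2 (beyond the scatter), modest and beyond the scatter. Next in line is compound 3 `CC[C@@H](Nc1c(C#N)c(-c2ccc(-c3cccc(OC)c3)cc2)nc2cnccc12)C(N)=O`, with 3-methoxyphenyl in place of 2-methoxyphenyl on an aromatic carbon, para to a large group. Within the data shown here, the measured step bears on this only in part, since it changes the group as well as its place, and no measured pair isolates the shift of the methoxy group alone. Compound 3 shares its numbering with the 3-chlorophenyl group of compound 1 at 3.1, so a small upward move is expected, smaller than the measured step. In this assay the expected change is a number 0.10 log units higher from compound 2 to compound 3 (within the scatter), probably within the scatter. The estimate for compound 3 is 2.8, with an expected range of 2.5 to 3.1.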

Compound 3, distribution coefficient: 2.7
Estimate against measurement, compound 3: 0.10 log units above; low and high end bracket the measured number.
By their numbers in this assay, from the lowest: compounds 2 and 3 (each within the scatter of the next); then compound 1.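

With 3-methoxyphenyl in place of 2-methoxyphenyl, this assay gives no change at the digits printed from compound 2 to compound 3 (within the scatter), so at this aromatic carbon, para to a large group, the shift of the methoxy group alone shows no measurable effect on the read-out. Methoxy in place of chloro, with the place of the group held constant, gives a number 0.40 log units lower from compound 1 to compound 3 (beyond the scatter); this is the first step that isolates the exchange of the group, and it suggests that the earlier step mixing group and place is tied to the group rather than to its place. No measurement shown offers an explanation for either step.

From the compounds shown here alone, whether the place matters as little for chloro stays open, and 2-chlorophenyl would test that. Going by these compounds, how an amine, a carboxylic acid or a longer ether chain at this place would read is also open.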